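Changing the piperazine side chain of compound 2

The compounds below may be only part of what the source reports. "The series", "measured", "known", "first", "only" and "open" are said of these compounds alone.

Compound 1 `O=C1c2c[n+]([O-])c3ccccc3c2C(=O)c2c1c1ccccc1n2CCCCN1CCNCC1` and compound 2 `CCCN1CCN(CCCCn2c3c(c4ccccc42)C(=O)c2c[n+]([O-])c4ccccc4c2C3=O)CC1` share one core and have both been tested in a functional assay on A-375 cells (Homo sapiens) for cytotoxicity, read by MTT assay, with a stated time of 72 h; on this read-out higher numbers stand for weaker inhibition and lower numbers for stronger inhibition. Going by the values given here, there compound 1 gives 460 nM and compound 2 gives 870 nM, which places compound 2 within the scatter of the only other measured compound. Among the compounds with values here, one measured step bears on what follows: a 1.9-fold higher number from compound 1 to compound 2 (0.28 log units; within the scatter), with propyl in place of hydrogen on an amine nitrogen in a ring. Compound 3 `CN1CCN(CCCCCn2c3c(c4ccccc42)C(=O)c2c[n+]([O-])c4ccccc4c2C3=O)CC1` differs from compound 2 by (4-methylpiperazin-1-yl)methyl in place of 4-propylpiperazin-1-yl on a saturated chain carbon, four bonds along the chain from an aromatic nitrogen. Within the data shown here, no measured step alters the chain, so that part of the change remains untested. The step to propyl covers the other part only loosely, yet it offers no ground for expecting a large shift. No step beyond the scatter is therefore expected in this assay. For compound 3 the expected value is 650 nM, with an estimated range of 280 nM to 1500 nM. This estimate means an expected 1.3-fold lower number from compound 2 to compound 3 (0.13 log units; within the scatter).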

Compound 3, half-maximal inhibitory concentration: 1710 nM
Compound 3: the middle estimate sits 2.6-fold (0.42 log units) below what was measured; measured number outside the range, above it.
By their numbers in this assay, from the lowest: compounds 1, 2 and 3 (each within the scatter of the next, the first and the last beyond it).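

At the saturated chain carbon, four bonds along the chain from an aromatic nitrogen, placing (4-methylpiperazin-1-yl)methyl where 4-propylpiperazin-1-yl stood gives a 2.0-fold higher number from compound 2 to compound 3 (0.29 log units; within the scatter) in this assay. Taken alone, this exchange therefore stays inside the usual variation, as the earlier step to propyl did. Going by these compounds alone, measured from the piperazin-1-yl group instead, the same place gives the first step beyond the scatter, a 3.7-fold higher number from compound 1 to compound 3 (0.57 log units; beyond the scatter), so the side chain of this series can register in this assay, though only modestly so far. Nothing available here accounts for this result.

On these data alone, because the changes to the chain and to the group on the ring nitrogen arrive together in compound 3, how the step divides between them remains open, and 4-methylpiperazin-1-yl on the chain of compound 2 would begin to separate them. As far as these compounds go, it is also open whether a shorter 3-(4-methylpiperazin-1-yl)propyl chain, or a morpholine or piperidine ring at the end of the chain, would stay within this narrow span of values.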